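Four analogues from one series, measured on breast cancer cells

The source may hold more compounds than are shown below. What is called first, only, known or untested is meant among the compounds shown, and "the series" means these compounds.

Compound 1, with the structure `COc1ccc(C(=O)/C(=C/c2ccc(Cl)cc2Cl)CC(C)OC(C)=O)cc1`, carries a 2,4-dichlorophenyl group and a 1-acetoxyethyl group on a short chain that joins a double bond to a carbonyl. In a functional assay on MCF7 cells (Homo sapiens) for inhibition, read by XTT assay, with a stated time of 48 h (on this read-out lower numbers stand for stronger inhibition and higher numbers for weaker inhibition), compound 1 gives > 100000 nM, which is a limit of the assay and not a number. Compound 2, `COc1ccc(C(=O)/C(=C/C2CCCCC2)CC(C)OC(C)=O)cc1`, differs from compound 1 by cyclohexyl in place of 2,4-dichlorophenyl on a double-bonded chain carbon bound to a double-bonded chain carbon. In this assay compound 2 gives > 100000 nM, again a limit. Compound 3, `COc1ccc(C(=O)/C(=C/c2ccc(Cl)cc2Cl)CN(C)C(=O)c2ccccc2)cc1`, differs from compound 1 by benzoyl(methyl)amino in place of 1-acetoxyethyl on a saturated chain carbon bound to a double-bonded chain carbon. In this assay compound 3 gives > 100000 nM, also a limit. The two measured steps are therefore a step that the two limits leave unreadable from compound 1 to compound 2 and a step that the two limits leave unreadable from compound 1 to compound 3, since all three values sit at the limit of > 100000 nM in this assay, at which 3 of the 3 values shown sit.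

Compound 4, `COc1ccc(C(=O)/C(=C/C2CCCCC2)CN(C)C(=O)c2ccccc2)cc1`, has not been measured. It differs from compound 3 by cyclohexyl in place of 2,4-dichlorophenyl on a double-bonded chain carbon bound to a double-bonded chain carbon, the same change that turns compound 1 into compound 2, made on the core of compound 3 rather than the core of compound 1. That change did not lift compound 2 off the limit, and compound 3 sits at the limit as well, so compound 4 is expected to stay there too. The step from compound 3 to compound 4 is estimated as a step that the limit leaves unreadable from compound 3 to compound 4. For compound 4 the expected value in this assay is 150000 nM, between 40000 nM and 600000 nM, most probably reported only as a limit.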

Compound 4, half-maximal inhibitory concentration: 32700 nM
For compound 4 the middle estimate is 4.6-fold (0.66 log units) above the measured one, outside the stated range (below it).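

In this assay, cyclohexyl in place of 2,4-dichlorophenyl, with benzoyl(methyl)amino on the saturated chain carbon, gives an at least 3.0-fold lower number from compound 3 to compound 4 (0.48 log units; beyond the scatter), so on this core the change brings a lower number by more than the usual scatter of repeated measurements. Compound 3 gives > 100000 nM, which is a limit and not a number, so the step has a known minimum but no known full size. The steps between compound 1 and compound 2 and between compound 1 and compound 3 cannot be read, so this single readable pair does not show that the change carries from one core to another, and the gain cannot be said to belong to cyclohexyl alone, because the matching step on the core of compound 1 stays hidden: the limit of > 100000 nM in this assay, at which 3 of the 4 values shown sit.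

A plain phenyl group in the same place would help to separate the loss of the two chlorine atoms from the loss of the aromatic ring, since the step from 2,4-dichlorophenyl to cyclohexyl changes both at once. Also open, going by these compounds, is whether cyclopentyl, piperidinyl or a longer alkyl chain in that place would give a lower number than compound 4, which gives 32700 nM in this assay.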